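The source may hold more compounds than are shown below. What is called first, only, known or untested is meant among the compounds shown, and "the series" means these compounds.

In a functional assay on ZR-75-1 cells (Homo sapiens) for cytotoxicity, read by MTT assay, with a stated time of 72 h (a higher number here means that more compound is needed for the effect, a lower number that less compound is needed), compound 1 `CCc1cccc2c(OC)c(-c3occ(C)c3C(=O)OC)ccc12` gives 1.3 ug/mL, and compound 2 `CCOC(=O)c1c(C)coc1-c1ccc2c(CC)cccc2c1OC` gives 3.9 ug/mL. The step of a 3.0-fold higher number from compound 1 to compound 2 (0.48 log units; beyond the scatter) goes with the change (methyl in place of hydrogen on a saturated chain carbon bound to an oxygen next to a carbonyl group). Compound 3 `CCc1cccc2c(OC)c(-c3occ(C)c3CO)ccc12` carries a hydroxymethyl group instead of the ester, the difference from compound 1 being (hydroxymethyl in place of methoxycarbonyl on an aromatic carbon). For compound 3 in this assay only a limit is reported, > 10 ug/mL. Against that limit the steps read an at least 7.6-fold higher number from compound 1 to compound 3 (0.88 log units; beyond the scatter) and an at least 2.5-fold higher number from compound 2 to compound 3 (0.40 log units; beyond the scatter); note (the limit of > 10 ug/mL in this assay, at which 1 of the 3 values shown sits).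

Compound 4 `CCOc1c(-c2occ(C)c2CO)ccc2c(CC)cccc12` is not yet measured. It differs from compound 3 by methyl in place of hydrogen on a saturated chain carbon bound to an oxygen on an aromatic ring. Among the compounds with values here, this is the same kind of change as the one from compound 1 to compound 2, but not the same: there the methyl entered on a saturated chain carbon bound to an oxygen next to a carbonyl group, here on a saturated chain carbon bound to an oxygen on an aromatic ring. The cores also differ, as given by hydroxymethyl in place of methoxycarbonyl on an aromatic carbon. Since the earlier change of this kind gave a modestly higher number, compound 4 is expected to show a step that the limit leaves unreadable from compound 3 to compound 4, and because compound 3 already stands at > 10 ug/mL the result for compound 4 is expected to be a limit again. The estimate for compound 4 in this assay is 20 ug/mL, between 8 ug/mL and 60 ug/mL.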

Compound 4, concentration for half-maximal effect: 1.4 ug/mL
Beside the measured number, compound 4's estimate is 14-fold (1.15 log units) above it; measured number below the stated range.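

In this assay, methyl in place of hydrogen on a saturated chain carbon bound to an oxygen on an aromatic ring, which turns methoxy into ethoxy, goes with an at least 7.1-fold lower number from compound 3 to compound 4 (0.85 log units; beyond the scatter). Set beside the earlier methyl step, this kind of change does not carry over from one core to the other, and the two steps run in opposite directions: the same change on two cores in this assay, a 3.0-fold higher number (0.48 log units; beyond the scatter) from compound 1 to compound 2 and an at least 7.1-fold lower number (0.85 log units; beyond the scatter) from compound 3 to compound 4, at least 21-fold (1.33 log units) apart, beyond the scatter of two such steps

Compound 3 stands at > 10 ug/mL, which is a limit and not a number, so the full size of the new step stays unknown, and the two methyl changes also sit in different places, which leaves it unshown whether place or core decides the outcome: the limit of > 10 ug/mL in this assay, at which 1 of the 4 values shown sits.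

The compounds shown leave open how ethoxy on the aromatic ring behaves alongside methoxycarbonyl, a pairing that would separate the place of the change from the core. Also open, from the compounds shown here alone, is whether a longer chain such as propoxy, or a carboxylic acid in place of the ester, would follow either step.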